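Trimming propyl to methyl: where compound 4 may land

The source may report more compounds than this note shows. Statements on the series, on what has been measured and on what is new or still open speak of the compounds shown alone.

Compound 1 `CNC(=O)c1cc(C(=O)N[C@H]2CC[C@H](OC)CC2)c([C@@H](C)c2ccccc2)o1` reads >= 192 ug/mL in a physicochemical assay for solubility (on this read-out lower numbers stand for lower solubility and higher numbers for higher solubility), a limit of the assay rather than a number.
Compound 3 `CNC(=O)c1cc(C(=O)N[C@H]2CC[C@H](O)CC2)c([C@@H](C)c2ccccc2)o1` reads >= 184 ug/mL in this assay, again a limit.
Compound 2 `CCCNC(=O)c1cc(C(=O)NC)nn1[C@@H](C)c1ccccc1` reads >= 132 ug/mL in this assay, also a limit.

All three measured values sit at limits, so none of them is a real number and no ranking among them can be read. Compound 2 is only known to lie at or beyond its limit, as are the two other values. Among the compounds with values here, the one single-point step that has been measured, a step that the two limits leave unreadable from compound 1 to compound 3, is unreadable for the same reason: both ends are limits, so its size cannot be told.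

Compound 4 `CNC(=O)c1cc(C(=O)NC)n([C@@H](C)c2ccccc2)n1` differs from compound 2 by hydrogen in place of ethyl on a saturated chain carbon bound to an amide-type nitrogen. Within the data shown here, no measured step touches a change of this kind, so there is nothing to compare it against beyond the general picture that every compound so far has exceeded its limit in this assay. On that basis compound 4 is expected to behave as the measured compounds do, with a step that the limit leaves unreadable from compound 2 to compound 4 that is most likely not readable at all. The estimate for compound 4 is therefore 200 ug/mL, with a range from 100 ug/mL to 400 ug/mL, and a high chance that the assay again reports only a limit.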

Compound 4, solubility: >= 88 ug/mL
Compound 4: no number, only a limit (the forecaster's own chance of this, stated with the estimate: 80%); the middle value does not contradict the limit.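

In this assay compound 4 gives >= 88 ug/mL, which is a limit and not a number. Compound 2 gives >= 132 ug/mL, also a limit. The step between compound 2 and compound 4 therefore cannot be read. The compounds shown leave open what the true solubility of each one is, and whether trimming propyl to methyl changes it at all.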